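The compounds below may be only part of what the source reports. "The series", "measured", "known", "first", "only" and "open" are said of these compounds alone.

Measured so far in a functional assay on cells (Hepatocyte, Rattus norvegicus) for inhibition, read by scintillation counting, with a stated time of 4 h; on this read-out higher numbers stand for weaker inhibition and lower numbers for stronger inhibition:
- compound 1 `Cc1ccccc1CNC(=O)c1nc(-c2ccc(F)cc2)n(CC[C@@H](O)C[C@@H](O)CC(=O)O)c1C1CC1`: 0.1 nM
- compound 2 `COc1ccc(CNC(=O)c2nc(-c3ccc(F)cc3)n(CC[C@@H](O)C[C@@H](O)CC(=O)O)c2C2CC2)cc1F`: 0.2 nM
- compound 3 `O=C(O)C[C@H](O)C[C@H](O)CCn1c(-c2ccc(F)cc2)nc(C(=O)NCc2ccc(F)c(F)c2)c1C1CC1`: 0.5 nM

Compound 3, at 0.5 nM, has the highest number of the three and is the weakest inhibitor in this small set. Compound 4 `O=C(O)C[C@H](O)C[C@H](O)CCn1c(-c2ccc(F)cc2)nc(C(=O)NCc2ccc(F)cc2)c1C1CC1` carries hydrogen in place of fluoro on an aromatic carbon. This turns the 3,4-difluorobenzyl group into 4-fluorobenzyl.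

Among the compounds with values here, no measured step makes this exact change, so the guide is the other changes on the same aromatic ring. The closest is the modest step of a 2.5-fold higher number from compound 2 to compound 3 (0.40 log units; beyond the scatter), which also exchanges a single aromatic group. The largest is the modest step of a 5.0-fold higher number from compound 1 to compound 3 (0.70 log units; beyond the scatter), while a 2.0-fold higher number from compound 1 to compound 2 (0.30 log units; within the scatter) stays within the scatter. With a smaller edit than any of these and no evidence for direction, no step beyond the scatter is expected, and the estimated change is a 1.3-fold lower number from compound 3 to compound 4 (0.10 log units; within the scatter). For compound 4 the estimated value is 0.4 nM, with an expected range of 0.13 nM to 1.2 nM.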

Compound 4, half-maximal inhibitory concentration: 0.7 nM
Estimate against measurement, compound 4: 1.8-fold (0.24 log units) below; low and high end bracket the measured number.
By their numbers in this assay, from the lowest: compounds 1 and 2 (each within the scatter of the next); then compounds 3 and 4 (each within the scatter of the next).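

In this assay, hydrogen in place of fluoro on the aromatic carbon ortho to a fluoro group gives a 1.4-fold higher number from compound 3 to compound 4 (0.15 log units; within the scatter), so compound 3 and compound 4 cannot be told apart, and this fluoro of the 3,4-difluorobenzyl group can go without a step beyond the scatter. The 4-fluorobenzyl group still stands apart from the other two benzyl groups, with a 3.5-fold higher number from compound 2 to compound 4 (0.54 log units; beyond the scatter) and a 7.0-fold higher number from compound 1 to compound 4 (0.85 log units; beyond the scatter), both modest, so the gaps seen earlier for compound 3 persist with this fluoro gone. Nothing on hand explains these gaps or the lack of a step at this position.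

Open, on these data alone, is whether chloro, trifluoromethyl or an amine on this aromatic carbon would stay within the scatter of compound 4. Also open, as far as these compounds go, is what hydrogen or another group would do in place of the remaining fluoro of the 4-fluorobenzyl group.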